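This account rests on a few compounds, and the source may have more. Where it says the series, first, only, none or still open, it means among the compounds named here.

Of the compounds shown here, three have so far been tested in an ADME assay on MRC5 cells (Homo sapiens) for cytotoxicity, read by resazurin assay, with a stated time of 72 h; on this read-out lower numbers stand for stronger inhibition and higher numbers for weaker inhibition: compound 1 `O=[N+]([O-])c1cn2c(n1)OC(COc1ccc(-c3ccc(F)cc3)nn1)CC2`, compound 2 `O=[N+]([O-])c1cn2c(n1)OC(COc1cccc(-c3ccc(F)nc3F)n1)CC2` and compound 3 `CC1(COC(=O)N2CCN(c3ccc(F)cc3)CC2)CCn2cc([N+](=O)[O-])nc2O1`. Compound 1 gives > 64000 nM, which is a limit and not a number. Compound 2 gives > 64000 nM, also a limit. Compound 3 gives > 64000 nM, again a limit, so its place cannot be ranked against the others. The whole set looks the same, with the limit of > 64000 nM in this assay, at which 3 of the 3 values shown sit.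

The next compound, compound 4 `O=C(OCC1CCn2cc([N+](=O)[O-])nc2O1)N1CCN(c2ccc(F)cc2)CC1`, differs from compound 3 in one place: hydrogen in place of methyl on a saturated ring carbon. In words, this is hydrogen in place of methyl on a saturated ring carbon. Going by the values given here, no measured pair shows what this swap does in this assay, so no step beyond the usual scatter is expected, in either direction. The expectation rests on all three measured compounds reaching the limit, and another limit reading is the likeliest result. For compound 4 the estimate is 64000 nM, with an expected range from 30000 nM to 100000 nM. That estimate means an expected step of a number no higher from compound 3 to compound 4 (the limit leaves the size open).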

Compound 4, half-maximal inhibitory concentration: > 64000 nM
Compound 4 was reported as a limit; the forecaster's own chance of this, stated with the estimate: 80%; the middle value lies on the limit itself.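

Compound 3 and compound 4 both read as a limit in this assay, so no step can be read for hydrogen in place of methyl on a saturated ring carbon. The set stays uniform: the limit of > 64000 nM in this assay, at which 4 of the 4 values shown sit. The compounds shown leave open what actual number any of them would give, and whether this swap changes it.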